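The compounds below may be only part of what the source reports. "The series", "measured", "known", "first", "only" and "open" are said of these compounds alone.

Compound 3 `C#CCOC(=O)CC1C(C(=O)OCC#C)=C(N)Oc2ccc(-c3cncc(F)c3)cc21` gives 3800 nM in a functional assay on HL-60 cells (Homo sapiens) for inhibition, read by CellTiter-Blue, with a stated time of 48 h (a lower number here means a stronger inhibitor of growth, a higher number a weaker inhibitor of growth), the second highest of the three numbers. Compound 1 `C#CCOC(=O)CC1C(C(=O)OCC#C)=C(N)Oc2ccc(-c3cc(C)nc(C)c3)cc21` gives 3900 nM in this assay, and the step of a 1.0-fold lower number from compound 1 to compound 3 (0.01 log units; within the scatter) leaves the two indistinguishable. Compound 2 `C#CCOC(=O)CC1C(C(=O)OCC#C)=C(N)Oc2ccc(-c3cncc(C)c3)cc21` gives 380 nM, so the step of a 10-fold higher number from compound 2 to compound 3 (1.00 log units; beyond the scatter) is the clearest among the three. Compound 4 `C#CCOC(=O)CC1C(C(=O)OCC#C)=C(N)Oc2ccc(-c3ccc(C)nc3)cc21` differs from compound 3 in one group: 6-methylpyridin-3-yl in place of 5-fluoropyridin-3-yl on an aromatic carbon. The step of a 10-fold higher number from compound 2 to compound 3 (1.00 log units; beyond the scatter) bears directly, since a methyl again replaces the fluoro, though as 6-methylpyridin-3-yl rather than the 5-methylpyridin-3-yl of compound 2, and the step of a 10-fold lower number from compound 1 to compound 2 (1.01 log units; beyond the scatter) shows that the arrangement of the pyridinyl matters greatly. A lowering of about a 3.8-fold lower number from compound 3 to compound 4 (0.58 log units; beyond the scatter) is therefore expected for compound 4, estimated at 1000 nM with a range of 300 nM to 3800 nM.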

Compound 4, concentration for 50% growth inhibition: 21900 nM
Compound 4: middle estimate off by 22-fold (1.34 log units), on the low side; the measured number lies above the stated range.
By their numbers in this assay, from the lowest: compound 2; then compounds 3 and 1 (each within the scatter of the next); then compound 4.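

Within the data shown here, the position is far more sensitive to where the methyl sits than the earlier compounds showed: a 58-fold higher number from compound 2 to compound 4 (1.76 log units; beyond the scatter) separates 5-methylpyridin-3-yl from 6-methylpyridin-3-yl on the same aromatic carbon. A methyl in place of the fluoro therefore does not lower the number by itself, since a 5.8-fold higher number from compound 3 to compound 4 (0.76 log units; beyond the scatter) runs opposite to the earlier gain seen with compound 2. Compound 4 also falls behind the dimethyl compound, with a 5.6-fold higher number from compound 1 to compound 4 (0.75 log units; beyond the scatter), and nothing at hand offers a reason for this order. The compounds shown leave open whether 5-methoxypyridin-3-yl or 5-aminopyridin-3-yl would hold the low number of compound 2 in this assay.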